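Working notes: cytotoxicity across three analogues

This account rests on a few compounds, and the source may have more. Where it says the series, first, only, none or still open, it means among the compounds named here.

Compound 1 `CCN(CC)c1cc2[nH]c(C3CCCCC3)nc2cc1NC(=O)c1ccc(F)cc1`: > 100 ug/mL
Compound 2 `CCOc1ccc(C(=O)Nc2cc3nc(C4CCCCC4)[nH]c3cc2N(CC)CC)cc1`: > 100 ug/mL

Both measured compounds were read in an ADME assay on Vero cells (Chlorocebus sabaeus) for cytotoxicity, read by resazurin assay, with a stated time of 3 days; a higher number here means a weaker inhibitor, a lower number a stronger inhibitor. For compound 1 the value > 100 ug/mL is a limit of the assay and not a number. For compound 2 the value > 100 ug/mL is likewise a limit and not a number. For the measured compounds named here, the one measured step, a step that the two limits leave unreadable from compound 1 to compound 2, cannot be sized because both of its ends sit at the limit of > 100 ug/mL in this assay, at which 2 of the 2 values shown sit. Compound 2 therefore stands only at that limit; nothing shown places it at a number.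

Compound 3 `CCCC(C)OC(=O)Nc1cc2nc(C3CCCCC3)[nH]c2cc1N(CC)CC` differs from compound 2 by 1-methylbutoxy in place of 4-ethoxyphenyl on a carbonyl carbon. Going by the values given here, the only measured step touches the aromatic ring that leaves here, and it is unreadable, so no measured step gives a readable size for this change. With every shown value sitting at the limit of > 100 ug/mL in this assay, at which 2 of the 2 values shown sit, the step of a number no higher from compound 2 to compound 3 (the limit leaves the size open) is expected to be none beyond the scatter, and the most likely outcome is again a limit rather than a number. Compound 3 is estimated at 100 ug/mL, with a range from 50 ug/mL to 200 ug/mL.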

Compound 3, half-maximal inhibitory concentration: > 100 ug/mL
Compound 3: no number, only a limit; the forecaster's own chance of this, stated with the estimate: 80%; the middle value sits exactly at the limit.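

In this assay compound 3 gives > 100 ug/mL as a limit and not a number. No new step can be read among compound 1, compound 2 and compound 3, because all of their values sit at one limit: the limit of > 100 ug/mL in this assay, at which 3 of the 3 values shown sit.

The compounds shown leave open how far each lies from that limit, and whether either exchange on the carbonyl carbon changes cytotoxicity at all.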